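Chloro ortho to the amino group on the aniline of compound 1

A few compounds are considered here, and "the series" means these few. Any claim that something is new, unique, unknown or untested is made for them only; others in the source may bear on it.

Measured compounds:
- compound 1, `Nc1ccc(-c2nc3cc(F)ccc3s2)cc1`: 11500 nM
- compound 2, `Cc1cc(-c2nc3ccc(F)cc3s2)ccc1N`: 1300 nM

In a functional assay on IGROV-1 cells (Homo sapiens) for inhibition (on this read-out lower numbers stand for stronger inhibition of growth and higher numbers for weaker inhibition of growth), compound 1 gives 11500 nM, the highest number of the two measured compounds. Compound 2 carries a methyl group and a different placement of the fluorine and gives 1300 nM, a lower number that lies beyond the scatter. The two compounds differ in two places. For the measured compounds named here, the two values show only that compound 2 inhibits growth more strongly.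

Compound 3, `Nc1ccc(-c2nc3cc(F)ccc3s2)cc1Cl`, is not yet measured. It differs from compound 1 as follows: chloro in place of hydrogen on an aromatic carbon. Going by the values given here, with no step between measured compounds that isolates this change, the expectation rests on the lower number of compound 2. A moderate step downward, beyond the scatter, is expected: a 3.3-fold lower number from compound 1 to compound 3 (0.52 log units; beyond the scatter). Compound 3 is estimated at 3500 nM, in a range from 1200 nM to 10000 nM.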

Compound 3, concentration for 50% growth inhibition: < 10 nM
Compound 3: only a limit was reported (the forecaster's own chance of this, stated with the estimate: 5%); at least 350-fold (2.54 log units) between middle value and limit.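

In this assay compound 3 gives < 10 nM, which is a limit of the assay and not a number. Chloro in place of hydrogen, ortho to an amino group, gives an at least 1100-fold lower number from compound 1 to compound 3 (3.06 log units; beyond the scatter); this is the first step to isolate one change, since compound 1 and compound 2 differ in two places, and it shows that this single position on the aromatic ring can carry a very large change in growth inhibition. The full size of the step stays unknown, as its end is set by a limit: the limit of < 10 nM in this assay, at which 1 of the 3 values shown sits.

The compounds shown leave open whether bromo, methoxy or a longer chain at this position would give a similar step. They also leave open whether chloro would give the same step with the fluorine placed as in compound 2.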